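This account rests on a few compounds, and the source may have more. Where it says the series, first, only, none or still open, it means among the compounds named here.

Working notes, series in a functional assay on HCT-116 cells (Homo sapiens) for cytotoxicity; a higher number here means a weaker inhibitor, a lower number a stronger inhibitor:

- Compound 1 `O=C1NC(=O)c2c1c1c3ccc(CN4CCNCC4)cc3[nH]c1c1c2c2cccc3c2n1CCC3`: > 10000 nM (a limit of the assay, not a number)
- Compound 2 `O=C1NC(=O)c2c1c1c3ccc(C(F)(F)F)cc3[nH]c1c1c2c2cccc3c2n1CCC3`: 1480 nM
- Compound 3 `O=C1NC(=O)c2c1c1c3ccc(CN4CCCC4)cc3[nH]c1c1c2c2cccc3c2n1CCC3`: 170 nM

Compound 3 holds the lower of the two actual numbers, and the gap to its nearest neighbour is an 8.7-fold lower number from compound 2 to compound 3 (0.94 log units; beyond the scatter). The remaining comparison is an at least 6.7-fold lower number from compound 1 to compound 2 (0.82 log units; beyond the scatter).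

Next is compound 4 `O=C1NC(=O)c2c1c1c3ccc(CN4CCCCC4)cc3[nH]c1c1c2c2cccc3c2n1CCC3`, with piperidin-1-yl in place of pyrrolidin-1-yl on a saturated chain carbon bound to an aromatic carbon.

The closest measured change at this place is pyrrolidin-1-yl in place of piperazin-1-yl, which gave an at least 58-fold lower number from compound 1 to compound 3 (1.76 log units; beyond the scatter). That size is only a bound, resting on (the limit of > 10000 nM in this assay, at which 1 of the 3 values shown sits). It shows that the ring on this carbon can matter a great deal in this assay, but it involves a different ring from the one entering here. The two steps involving trifluoromethyl replace the whole group and bear on this change only loosely.

No step beyond the scatter is the likeliest outcome, with a slight lean towards a higher number. The expected step is a 1.4-fold higher number from compound 3 to compound 4 (0.15 log units; within the scatter). The estimate for compound 4 is 240 nM, with an expected range of 80 nM to 800 nM.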

Compound 4, half-maximal inhibitory concentration: 320 nM
Compound 4: the middle estimate sits 1.3-fold (0.12 log units) below what was measured; measured number inside the range.
By their numbers in this assay, from the lowest: compounds 3 and 4 (each within the scatter of the next); then compound 2. At a limit, above all of these: compound 1.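

In this assay, enlarging the ring on this saturated chain carbon gives a 1.9-fold higher number from compound 3 to compound 4 (0.27 log units; within the scatter), so pyrrolidin-1-yl and piperidin-1-yl are not told apart here, and the position accepts either ring. Compound 4 also keeps the gains that compound 3 showed over the other two groups, with a 4.6-fold lower number from compound 2 to compound 4 (0.67 log units; beyond the scatter) against trifluoromethyl and an at least 31-fold lower number from compound 1 to compound 4 (1.49 log units; beyond the scatter) against the piperazin-1-yl ring, so the sharp loss at this position now stands out as belonging to compound 1 alone among the three ring-bearing compounds. The value of compound 1 is a limit and not a number, so the step from it gives only a bound on the size: the limit of > 10000 nM in this assay, at which 1 of the 4 values shown sits.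

The compounds shown leave open whether the loss in compound 1 follows from the second ring nitrogen itself, which 4-methylpiperazin-1-yl or morpholin-4-yl on the same carbon would help to test. Also open, from the compounds shown here alone, is how an open-chain amine such as dimethylamino, or a longer chain carrying the pyrrolidin-1-yl ring, would compare with compound 3 and compound 4.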